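The source may report more compounds than this note shows. Statements on the series, on what has been measured and on what is new or still open speak of the compounds shown alone.

Compound 1, `COC(=O)N[C@H](C(=O)NN(CCC[C@@](O)(Cc1ccccc1)C(=O)N[C@H]1c2ccccc2C[C@H]1O)Cc1ccc(C#N)cc1)C(C)(C)C`, was tested in an ADME assay on MT4 cells (Homo sapiens) for cytotoxicity; a lower number here means that less compound is tolerated, a higher number that more compound is tolerated. In this assay compound 1 gives > 10000 nM, a value that is only a limit of the assay and not a measured number. Compound 2, `COC(=O)N[C@H](C(=O)NN(CCC[C@@](O)(Cc1ccccc1)C(=O)N[C@H]1c2ccccc2C[C@H]1O)Cc1ccc(N(C)C)cc1)C(C)(C)C`, carries dimethylamino in place of cyano on an aromatic carbon; in this assay compound 2 gives > 10000 nM, again a limit rather than a number. The step from compound 1 to compound 2 is therefore a step that the two limits leave unreadable from compound 1 to compound 2, and its size cannot be read, since (the limit of > 10000 nM in this assay, at which 2 of the 2 values shown sit).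

Compound 3, `COC(=O)N[C@H](C(=O)NN(CCC[C@@](O)(Cc1ccccc1)C(=O)N[C@H]1c2ccccc2C[C@H]1O)Cc1ccc(-c2ccsc2)cc1)C(C)(C)C`, differs from compound 1 as follows: thiophen-3-yl in place of cyano on an aromatic carbon. Going by the values given here, no measured step in this assay bears on a change of this kind; the one step known, between compound 1 and compound 2, sits entirely at the limit and shows only that both compounds are tolerated up to it. For compound 3 the expectation is a step of about a number no higher from compound 1 to compound 3 (the limit leaves the size open), which means no change beyond the scatter, and compound 3 is therefore expected to give roughly 10000 nM in this assay, within a range from 3000 nM to 30000 nM.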

Compound 3, half-maximal cytotoxic concentration: > 10000 nM
Compound 3 gave a limit, no number; the forecaster's own chance of this, stated with the estimate: 60%; the middle value sits exactly at the limit.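

In this assay compound 3 gives > 10000 nM, which is a limit and not a number. Going by these compounds alone, no step among compound 1, compound 2 and compound 3 can be read, since all three sit at the same limit: the limit of > 10000 nM in this assay, at which 3 of the 3 values shown sit. The compounds shown leave open whether cyano, dimethylamino and thiophen-3-yl differ at all in how much compound the cells tolerate.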